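The source may report more compounds than this note shows. Statements on the series, on what has been measured and on what is new or still open speak of the compounds shown alone.

Of the compounds shown here, three built on one shared core have been tested in a functional assay on MCF7 cells (Homo sapiens) for cytotoxicity, read by sulforhodamine B assay; on this read-out lower numbers stand for stronger inhibition of growth and higher numbers for weaker inhibition of growth. Compound 1 `CC1=CC[C@@H]([C@@](C)(O)CCCC(C)(C)NC(=S)N/N=C\c2ccc(O)cc2)CC1` carries a 4-hydroxyphenyl on the carbon with a double bond to nitrogen and gives 21200 nM. Compound 3 `CC1=CC[C@@H]([C@@](C)(O)CCCC(C)(C)NC(=S)N/N=C\c2cccc([N+](=O)[O-])c2)CC1` carries a 3-nitrophenyl there and gives 18300 nM, the lowest of the two plain numbers, though a 1.2-fold lower number from compound 1 to compound 3 (0.06 log units; within the scatter) leaves compound 1 and compound 3 indistinguishable. Compound 2 `CC1=CC[C@@H]([C@@](C)(O)CCCC(C)(C)NC(=S)N/N=C\c2ccccc2[N+](=O)[O-])CC1`, with a 2-nitrophenyl, reaches only a limit of this assay, > 100000 nM. Because of that limit of > 100000 nM in this assay, at which 1 of the 3 values shown sits, the steps of an at least 4.7-fold higher number from compound 1 to compound 2 (0.67 log units; beyond the scatter) and an at least 5.4-fold lower number from compound 2 to compound 3 (0.73 log units; beyond the scatter) are known only as minimum sizes.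

Compound 4 `CC1=CC[C@@H]([C@@](C)(O)CCCC(C)(C)NC(=S)N/N=C\c2ccccc2Cl)CC1` is not yet measured. It differs from compound 3 in one place: 2-chlorophenyl in place of 3-nitrophenyl on a carbon with a double bond to nitrogen. Going by the values given here, the steps that bear on this change are the two involving compound 2, which show that a 2-nitrophenyl weakened growth inhibition markedly compared with either 4-hydroxyphenyl or 3-nitrophenyl. Among the compounds with values here, a 2-chlorophenyl is not a 2-nitrophenyl, and no compound here carries chlorine, so the guide is loose. Still, a weakening is expected for compound 4 in this assay, estimated at a 2.2-fold higher number from compound 3 to compound 4 (0.34 log units; beyond the scatter), smaller than what compound 2 showed. Compound 4 is therefore expected to give about 40000 nM, likely between 15000 nM and 110000 nM.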

Compound 4, concentration for total growth inhibition: > 100000 nM
Compound 4 was reported as a limit; the forecaster's own chance of this, stated with the estimate: 30%; middle value at least 2.5-fold (0.39 log units) away from the limit.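

In this assay the loss of growth inhibition seen with compound 2 now appears with a second group at this place, a 2-chlorophenyl, which carries no nitrogen or oxygen. Swapping the 3-nitrophenyl for it gives a step beyond the scatter (an at least 5.4-fold higher number from compound 3 to compound 4 (0.73 log units; beyond the scatter)), and swapping the 4-hydroxyphenyl for it gives another (an at least 4.7-fold higher number from compound 1 to compound 4 (0.67 log units; beyond the scatter)), both known only as minimum sizes. Going by these compounds alone, until now the weak result rested on one nitro compound and could have belonged to the nitro group itself; now, across these four compounds, the 2-nitrophenyl and the 2-chlorophenyl both reach the limit of the assay, the 3-nitrophenyl and the 4-hydroxyphenyl both give plain numbers, and no compound goes against this.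

The compounds shown leave open whether a 3-chlorophenyl or a 4-chlorophenyl would give a plain number as compound 3 does, and whether a 2-methylphenyl or a 2-fluorophenyl would also reach the limit. How compound 2 and compound 4 compare also stays open, and the step between them cannot be read, because both sit at the same limit: the limit of > 100000 nM in this assay, at which 2 of the 4 values shown sit.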